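The compounds below may be only part of what the source reports. "The series", "measured", "known", "first", "only" and "open" are said of these compounds alone.

In an ADME assay (liver) for metabolic stability, with Liver microsome (Homo sapiens) as the target, using microsomes and NADPH, with a stated time of 30 min, tested at 1 uM (a higher number here means faster removal of the compound, a lower number slower removal), compound 1 `COc1cc(C(O)(C(F)(F)F)C(F)(F)F)cnc1N1CCN(S(=O)(=O)c2ccc(N)nc2)CC1` is reported only as a limit, < 14 mL.min-1.g-1. Compound 2 `CC(C)n1cc(-c2cc(C(O)(C(F)(F)F)C(F)(F)F)cnc2N2CCN(S(=O)(=O)c3ccc(N)nc3)CC2)cn1`, with 1-isopropyl-1H-pyrazol-4-yl in place of methoxy, gives 38 mL.min-1.g-1. Compound 3 `CC(C)(C)n1cc(-c2cc(C(O)(C(F)(F)F)C(F)(F)F)cnc2N2CCN(S(=O)(=O)c3ccc(N)nc3)CC2)cn1` gives 86 mL.min-1.g-1, the highest number among these compounds. The pyrazole steps are an at least 2.7-fold higher number from compound 1 to compound 2 (0.43 log units; beyond the scatter) and an at least 6.1-fold higher number from compound 1 to compound 3 (0.78 log units; beyond the scatter), and the single added methyl gives a 2.3-fold higher number from compound 2 to compound 3 (0.35 log units; beyond the scatter).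

Compound 4 `Nc1ccc(S(=O)(=O)N2CCN(c3ncc(C(O)(C(F)(F)F)C(F)(F)F)cc3-c3ccccc3O)CC2)cn1` changes the same aromatic carbon, with 2-hydroxyphenyl in place of 1-(tert-butyl)-1H-pyrazol-4-yl on an aromatic carbon. All three measured steps bear on this change, though none of them introduces 2-hydroxyphenyl, so the evidence is indirect. Removing the methyl alone accounts for a 2.3-fold higher number from compound 2 to compound 3 (0.35 log units; beyond the scatter), and compound 4 loses the whole pyrazole group. A fall of similar or somewhat larger size is therefore expected, while a return to the limit of compound 1 seems less likely. The expected change is a 2.5-fold lower number from compound 3 to compound 4 (0.39 log units; beyond the scatter). Compound 4 is estimated at 35 mL.min-1.g-1, within an expected range of 15 mL.min-1.g-1 to 80 mL.min-1.g-1.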

Compound 4, intrinsic clearance in microsomes: 22 mL.min-1.g-1
For compound 4 the middle estimate is 1.6-fold (0.20 log units) above the measured one; the measured number falls inside the stated range.
By their numbers in this assay, from the lowest: compounds 4 and 2 (each within the scatter of the next); then compound 3. At a limit, below all of these: compound 1.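

The position is not tied to a pyrazole: with 2-hydroxyphenyl on this aromatic carbon, the step from the tert-butyl pyrazole is a 3.9-fold lower number from compound 3 to compound 4 (0.59 log units; beyond the scatter). In this assay, the step from the isopropyl pyrazole is a 1.7-fold lower number from compound 2 to compound 4 (0.24 log units; within the scatter), so the swap of pyrazole for a six-membered carbon ring cannot be told apart from the scatter in that pair, and the larger drop holds only against compound 3. Compound 1 is known only as a limit, so the comparison with it, an at least 1.5-fold higher number from compound 1 to compound 4 (0.19 log units; that floor lies within the scatter), gives a floor that fixes no firm order: the limit of < 14 mL.min-1.g-1 in this assay, at which 1 of the 4 values shown sits.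

Left open is how a plain phenyl, lacking the hydroxy group, would read on this aromatic carbon in this assay. Also open, going by these compounds, is where an amine or a carboxylic acid on that ring would fall.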